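The compounds below may be only part of what the source reports. "The series", "measured", "known", "first", "only" and "open" are said of these compounds alone.

Measured so far in this series:
- compound 1 `COc1cc(CNC(=O)/C=C/c2cccc(O)c2)ccc1OCc1nc(C)c(C)nc1C`: 3680 nM
- compound 2 `COc1cc(/C=C/C(=O)NCc2ccc(OCc3nc(C)c(C)nc3C)c(OC)c2)cc(OC)c1`: 8660 nM
- compound 3 `COc1cc(CNC(=O)/C=C/c2ccc(OC)c(OC)c2OC)ccc1O`: 7450 nM

In a functional assay on SH-SY5Y cells (Homo sapiens) for cytotoxicity, read by MTT assay, with stated times of 24 h and 4 h (on this read-out higher numbers stand for an effect only at larger amounts of compound and lower numbers for an effect already at smaller amounts), compound 3 holds the second highest of the three numbers; its gap to compound 2 is within the scatter, while compound 1 sits lower by a margin beyond it. Compound 4 `COc1cc(CNC(=O)/C=C/c2ccc(OC)c(OC)c2OC)ccc1OCc1nc(C)c(C)nc1C` differs from compound 3 by (3,5,6-trimethylpyrazin-2-yl)methyl in place of hydrogen on an oxygen on an aromatic ring. Within the data shown here, the one measured step, a 2.4-fold higher number from compound 1 to compound 2 (0.37 log units; beyond the scatter), changes the aryl on the double-bonded chain carbon and leaves the oxygen on the aromatic ring untouched, so no measured step bears directly on this change; compounds 1 and 2 both already carry the entering group and no pair isolates it. A step of no more than the scatter is therefore expected, a 1.1-fold lower number from compound 3 to compound 4 (0.06 log units; within the scatter). For compound 4 the estimate in this assay is 6500 nM, with a range of 2800 nM to 15000 nM.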

Compound 4, half-maximal effective concentration: 3840 nM
Compound 4: the middle estimate sits 1.7-fold (0.23 log units) above what was measured, within the range that was stated.
By their numbers in this assay, from the lowest: compounds 1, 4, 3 and 2 (each within the scatter of the next, the first and the last beyond it).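

In this assay, the first direct read on this oxygen, (3,5,6-trimethylpyrazin-2-yl)methyl in place of hydrogen gives a 1.9-fold lower number from compound 3 to compound 4 (0.29 log units; within the scatter) and stays within the scatter. With that group in place, the aryl swaps read differently: 2,3,4-trimethoxyphenyl for 3,5-dimethoxyphenyl gives a 2.3-fold lower number from compound 2 to compound 4 (0.35 log units; beyond the scatter) and lies beyond the scatter, while 2,3,4-trimethoxyphenyl for 3-hydroxyphenyl gives a 1.0-fold higher number from compound 1 to compound 4 (0.02 log units; within the scatter) and stays within it. No measurement at hand accounts for these steps.

Open, going by these compounds, is how an amine or a carboxylic acid on a longer chain at this oxygen would read. Also open, on these data alone, is whether the aryl steps hold with the free hydroxy.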